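Hydroxypropyl for benzyl on a triazole-linked aryl series

This account rests on a few compounds, and the source may have more. Where it says the series, first, only, none or still open, it means among the compounds named here.

Compound 1 `FC(F)(F)c1ccc(-c2cn(Cc3ccccc3)nn2)cc1` and compound 2 `OCCCn1cc(-c2ccc(C(F)(F)F)cc2)nn1` share a core whose difference from that of compound 3 `c1ccc(Cn2cc(-c3ccc4ccccc4c3)nn2)cc1` is not broken down here. In a functional assay on B16 cells (Mus musculus) for cytotoxicity, read by MTT assay, with a stated time of 48 h (on this read-out higher numbers stand for weaker inhibition and lower numbers for stronger inhibition), compound 1 reaches only a limit, > 100000 nM. In this assay compound 2 likewise reaches only a limit, > 100000 nM. In this assay, within the data shown here, compound 3 gives 3890 nM, the only number among the three measured values. The change from compound 1 to compound 2, (2-hydroxyethyl in place of phenyl on a saturated chain carbon bound to an aromatic nitrogen), gives a step that the two limits leave unreadable from compound 1 to compound 2; because the limit of > 100000 nM in this assay, at which 2 of the 3 values shown sit, holds both ends of that pair, its size cannot be read.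

Compound 4 `OCCCn1cc(-c2ccc3ccccc3c2)nn1` is not yet measured. It carries the same kind of change on the core of compound 3: 2-hydroxyethyl in place of phenyl on a saturated chain carbon bound to an aromatic nitrogen. The two places are described in the same words. Among the measured compounds shown here, the only measured pair with this change leaves its size unreadable, so no step size is carried over from compound 1 and compound 2; the expectation for compound 4 rests on the value of compound 3, 3890 nM, as the starting point and on the fact that the only number in the set belongs to the benzyl-bearing compound 3. A step of a 5.1-fold higher number from compound 3 to compound 4 (0.71 log units; beyond the scatter) toward weaker inhibition is expected. In this assay compound 4 is estimated at 20000 nM, with a range from 4000 nM to 100000 nM, and a fair chance that only a limit is returned.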

Compound 4, half-maximal inhibitory concentration: > 100000 nM
Compound 4: no number, only a limit (the forecaster's own chance of this, stated with the estimate: 35%); at least 5.0-fold (0.69 log units) between middle value and limit.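

On the core of compound 3, 3-hydroxypropyl in place of benzyl gives an at least 25-fold higher number from compound 3 to compound 4 (1.41 log units; beyond the scatter) in this assay, so on the only core with a measured starting number the change goes with a large move toward weaker inhibition. Compound 4 returns only a limit, > 100000 nM, so the step has a lower bound and no exact size. This does not show that the change has the same size on both cores, since the step from compound 1 to compound 2 cannot be read and the two steps cannot be compared, because compound 1, compound 2 and compound 4 all sit at one limit: the limit of > 100000 nM in this assay, at which 3 of the 4 values shown sit.

The compounds shown leave open whether the step goes with the loss of the phenyl or with the entry of the hydroxyl, and a plain propyl chain on the core of compound 3 would separate the two. They also leave open whether any group other than benzyl keeps a readable number on that core, for example a longer chain carrying a hydroxyl, a 3-aminopropyl group or a chain bearing a carboxylic acid.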